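The compounds below may be only part of what the source reports. "The series", "measured", "known", "first", "only" and "open" are said of these compounds alone.

In a functional assay on PC-3 cells (Homo sapiens) for inhibition, read by MTT assay, with a stated time of 72 h (on this read-out higher numbers stand for weaker inhibition and lower numbers for stronger inhibition), compound 1 `O=C(CSc1nc(Nc2ccccc2)c2ccccc2n1)Nc1cccc(Br)c1` gives 11400 nM; compound 2 `C=CC(=O)Nc1cccc(NC(=O)CSc2nc(Nc3ccccc3)c3ccccc3n2)c1` gives 8740 nM.

For the measured compounds named here, compound 2 stands alongside compound 1 on the two numbers in hand: the single measured step, a 1.3-fold lower number from compound 1 to compound 2 (0.12 log units; within the scatter), lies within the scatter, so the two compounds cannot be told apart in this assay. Compound 3 `O=C(CSc1nc(Nc2ccccc2)c2ccccc2n1)Nc1ccc(C(F)(F)F)cc1` has not yet been measured. It differs from compound 2 in one place: 4-(trifluoromethyl)phenyl in place of 3-((vinylcarbonyl)amino)phenyl on an amide-type nitrogen. Going by the values given here, the only step available, a 1.3-fold lower number from compound 1 to compound 2 (0.12 log units; within the scatter), swaps a different group and bears on this change only loosely; it was within the scatter. Nothing in the data marks out the 4-(trifluoromethyl)phenyl group, so the expectation is a step of no more than the scatter in either direction. Compound 3 is therefore estimated to give 10000 nM in this assay, with a range from 3500 nM to 30000 nM. The expected step is then a 1.1-fold higher number from compound 2 to compound 3 (0.06 log units; within the scatter).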

Compound 3, half-maximal inhibitory concentration: 10400 nM
The estimate for compound 3 lay 1.0-fold (0.02 log units) below the measured number; the range from low to high includes it.
By their numbers in this assay, from the lowest: compounds 2, 3 and 1 (each within the scatter of the next).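

On the amide-type nitrogen, 4-(trifluoromethyl)phenyl in place of 3-((vinylcarbonyl)amino)phenyl gives a 1.2-fold higher number from compound 2 to compound 3 (0.08 log units; within the scatter) in this assay, so the two groups cannot be told apart here. With 4-(trifluoromethyl)phenyl in place of 3-bromophenyl, the result is a 1.1-fold lower number from compound 1 to compound 3 (0.04 log units; within the scatter), which leaves all three groups at this place within the scatter of one another, even though the entering group has no hydrogen-bond donor or acceptor and 3-((vinylcarbonyl)amino)phenyl has one of each. Nothing measured alongside these numbers offers an explanation for this result.

Going by these compounds, what remains open is whether any group at this place can separate itself from these three substituted phenyl groups. An aminophenyl or carboxyphenyl group or a plain alkyl chain on that nitrogen might do so, and the effect of changes to the shared core is equally unknown.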